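The source may report more compounds than this note shows. Statements on the series, on what has been measured and on what is new or still open speak of the compounds shown alone.

Compound 1 (`Cc1nc(SCC(=O)Nc2nc(-c3ccc(Cl)cc3)cs2)n(Nc2ccccc2)c1C`) holds the only plain number shown in a functional assay on TK-10 cells (Homo sapiens) for antiproliferative activity, read by sulforhodamine B assay, with a stated time of 48 h (on this read-out higher numbers stand for lower toxicity in this test and lower numbers for higher toxicity in this test), where compound 1 gives 40700 nM. Compound 2 (`Cc1ccc(Nn2c(SCC(=O)Nc3nc(-c4ccccc4)cs3)nc(C)c2C)cc1`) is reported in this assay only as a limit, > 100000 nM, and this is the limit of > 100000 nM in this assay, at which 1 of the 2 values shown sits. Compound 3 (`COc1ccc(Nn2c(SCC(=O)Nc3nc(-c4ccc(Cl)cc4)cs3)nc(C)c2C)cc1`) differs from compound 1 by methoxy in place of hydrogen on an aromatic carbon. For the measured compounds named here, no measured pair shows this change, so in this assay the expected step is a 1.5-fold higher number from compound 1 to compound 3 (0.17 log units; within the scatter), a modest loss of toxicity at the edge of the scatter. Compound 3 is accordingly estimated at 60000 nM, within 20000 nM to 150000 nM.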

Compound 3, concentration lethal to 50% of the cells: > 100000 nM
Compound 3: no number, only a limit (the forecaster's own chance of this, stated with the estimate: 40%); middle value at least 1.6-fold (0.22 log units) away from the limit.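

In this assay, for the compounds shown here, methoxy in place of hydrogen on the aromatic carbon para to a large group, anilino to (4-methoxyphenyl)amino, gives an at least 2.4-fold higher number from compound 1 to compound 3 (0.39 log units; beyond the scatter), the first measured step at this position. It shows that this single change moves the read-out towards lower toxicity by more than the usual scatter. Compound 3 is reported only as a limit, one shared within this small set: the limit of > 100000 nM in this assay, at which 2 of the 3 values shown sit.

Going by these compounds, the true size of the step therefore stays open. So does the outcome with a fluorine atom or an amine at this position.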